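Notes on the 2-methylphenyl step from compound 1

A few compounds are considered here, and "the series" means these few. Any claim that something is new, unique, unknown or untested is made for them only; others in the source may bear on it.

Measured in a functional assay on B16 cells (Mus musculus), read by spectrophotometry, with a stated time of 3 days; on this read-out higher numbers stand for weaker inhibition and lower numbers for stronger inhibition:
- compound 1 `Cc1ccc(NC(=S)N/N=C/c2cccc3ccccc23)cc1`: 580 nM
- compound 2 `S=C(N/N=C/c1cccc2ccccc12)Nc1ccc(Cl)cc1`: 1900 nM
- compound 3 `COc1cccc(NC(=S)N/N=C/c2cccc3ccccc23)c1`: 830 nM

Compound 1 stands at the low end of these values, with a 1.4-fold higher number from compound 1 to compound 3 (0.16 log units; within the scatter) and a 3.3-fold higher number from compound 1 to compound 2 (0.52 log units; beyond the scatter). Compound 4 `Cc1ccccc1NC(=S)N/N=C/c1cccc2ccccc12` carries 2-methylphenyl in place of 4-methylphenyl on an amide-type nitrogen. Within the data shown here, no measured step makes this exact change. The closest evidence is the aryl change at that nitrogen, a 1.4-fold higher number from compound 1 to compound 3 (0.16 log units; within the scatter), and the chloro in place of methyl, a 3.3-fold higher number from compound 1 to compound 2 (0.52 log units; beyond the scatter). Both of these moves away from compound 1 raise the number, so a small rise is expected in this assay. The estimated step is a 1.4-fold higher number from compound 1 to compound 4 (0.14 log units; within the scatter). The expected value for compound 4 is 800 nM, with an estimated range of 300 nM to 2200 nM.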

Compound 4, half-maximal inhibitory concentration: 490 nM
Estimate against measurement, compound 4: 1.6-fold (0.21 log units) above; the measured number falls inside the stated range.
By their numbers in this assay, from the lowest: compounds 4, 1 and 3 (each within the scatter of the next); then compound 2.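

In this assay, the exchange of 4-methylphenyl for 2-methylphenyl on the amide-type nitrogen gives a step within the scatter (a 1.2-fold lower number from compound 1 to compound 4 (0.07 log units; within the scatter)), so these two placements of the methyl cannot be told apart here. The step of a 1.7-fold lower number from compound 3 to compound 4 (0.23 log units; within the scatter) is also within the scatter, while a 3.9-fold lower number from compound 2 to compound 4 (0.59 log units; beyond the scatter) is beyond it, which leaves the 4-chlorophenyl compound apart from compound 4 as well. No evidence at hand accounts for these values.

Still open, going by these compounds, is how an amine or a carboxylic acid in place of the methyl would read. Also open, on these data alone, is whether a longer chain there, such as propyl, would stay within the scatter of compound 4.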